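Swapping the Heterocycle on the Chain Carbon of Compound 2

The compounds below may be only part of what the source reports. "The series", "measured", "known", "first", "only" and "open" are said of these compounds alone.

Of the compounds shown here, two that share a peptide-like core have been tested in a functional assay on Jurkat cells (Homo sapiens) for inhibition; a higher number here means a weaker inhibitor, a lower number a stronger inhibitor. Compound 1 `CC(C)[C@H](NC(=O)COc1cccc2ccccc12)C(=O)N[C@@H](CC(=O)O)C(=O)CSc1nc(-c2ccccc2)c(-c2ccccc2)o1` gives only a limit in this assay, > 200000 nM. Compound 2 `CC(C)[C@H](NC(=O)COc1cccc2ccccc12)C(=O)N[C@@H](CC(=O)O)C(=O)CSc1nc2ccccc2s1` likewise gives only a limit in this assay, > 200000 nM. Among the compounds with values here, compound 2 therefore stands not at a measured number but at the edge of what this assay reports, and the one other value shown sits in the same place (the limit of > 200000 nM in this assay, at which 2 of the 2 values shown sit). Within the data shown here, no step between two measured compounds is available, so the only guidance for compound 3 `CC(C)[C@H](NC(=O)COc1cccc2ccccc12)C(=O)N[C@@H](CC(=O)O)C(=O)COn1nnc2ccccc2c1=O` is the structural change itself: a group of 12 heavy atoms (7 carbon, 3 nitrogen, 2 oxygen; one six-membered aromatic ring of carbon only, one six-membered aromatic ring with 3 hetero atoms) in place of a group of 10 heavy atoms (7 carbon, 1 nitrogen, 2 sulfur; one five-membered aromatic ring with 2 hetero atoms, one six-membered aromatic ring of carbon only), on a saturated chain carbon bound to a carbonyl carbon. With compound 2 at the limit, the step of a number no higher from compound 2 to compound 3 (the limit leaves the size open) is expected to be none beyond the scatter, in neither direction, and it is estimated that compound 3 will most likely again return only a limit. Compound 3 is expected to give about 200000 nM in this assay, with a range from 50000 nM to 1000000 nM.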

Compound 3, half-maximal inhibitory concentration: 137000 nM
Beside the measured number, compound 3's estimate is 1.5-fold (0.16 log units) above it, within the range that was stated.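

In this assay compound 3 is the only one of the compounds shown that returns a number rather than a limit, 137000 nM. On this saturated chain carbon bound to a carbonyl carbon, replacing (1,3-benzothiazol-2-yl)sulfanyl with the larger group carrying a six-membered aromatic ring with 3 hetero atoms gives an at least 1.4-fold lower number from compound 2 to compound 3 (0.16 log units; that floor lies within the scatter), so the position accepts a change of ring and of linking atom, but the step is known only as a floor and shows no difference beyond the scatter. The change therefore establishes a measurable value for one group at this position and no more, while the other two compounds remain at the edge of what the assay reports: the limit of > 200000 nM in this assay, at which 2 of the 3 values shown sit.

As far as these compounds go, the true size of the step stays open, as does the question of which part of the entering group matters, its ring with 3 hetero atoms or the oxygen atom that ties it to the chain. From the compounds shown here alone, whether a simpler group on this carbon, such as a phenoxy group or a single fluorine atom, would give a number well clear of the limit also remains open.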